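The source may hold more compounds than are shown below. What is called first, only, known or untested is meant among the compounds shown, and "the series" means these compounds.

In a functional assay on HCT-15 cells (Homo sapiens) (a higher number here means that more compound is needed for the effect, a lower number that less compound is needed), compound 1 (`COc1cc(C2OC(c3ccccc3N(C)C)=NN2C(C)=O)cc(OC)c1OC`) gives 65 uM and compound 2 (`CCOC(=O)C(=O)N1N=C(c2ccc(N(C)C)cc2)OC1c1cc(OC)c(OC)c(OC)c1`) gives 45 uM as its number, so these two values lie within the usual scatter of each other and neither compound can be ranked above the other. Compound 3 (`COc1cc(C2OC(c3ccc(N(C)C)cc3)=NN2C(=O)CNC=O)cc(OC)c1OC`) has one change from compound 2 ((formylamino)methyl in place of ethoxycarbonyl on a carbonyl carbon): (formylamino)methyl in place of ethoxycarbonyl on a carbonyl carbon. Among the compounds with values here, no measured pair differs in only one place, so the data show no direct precedent for this swap. Compound 1 at 65 uM and compound 2 at 45 uM stay close despite carrying different groups on that carbonyl carbon, so no step beyond the scatter is expected in either direction. The estimated shift is a 1.1-fold higher number from compound 2 to compound 3 (0.05 log units; within the scatter) and stays within the scatter. For compound 3 the estimated value is 50 uM with an expected range from 20 uM to 110 uM in the same read-out.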

Compound 3, concentration for half-maximal effect: 0.035 uM
For compound 3 the middle estimate is 1400-fold (3.15 log units) above the measured one; the measured number lies below the stated range.
By their numbers in this assay, from the lowest: compound 3; then compounds 2 and 1 (each within the scatter of the next).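

In this assay, replacing ethoxycarbonyl with (formylamino)methyl on the carbonyl carbon gives a 1300-fold lower number from compound 2 to compound 3 (3.11 log units; beyond the scatter) and shows that the group held here can matter greatly. Compound 1 and compound 2 could not reveal this, as they differ in more than one place and their values lie within the scatter of each other. The entering group carries a hydrogen-bond donor that ethoxycarbonyl lacks, but nothing available ties the step to that donor or to any other feature of the swap. From the compounds shown here alone, it remains open which part of (formylamino)methyl goes with the step, since this single swap changes the whole group at once. A plain aminomethyl group, with a free amine, or a longer chain ending in the same formylamino unit on this carbonyl carbon would help separate the possibilities.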